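A Halogen Swap on the Saturated Ring Carbon

This account rests on a few compounds, and the source may have more. Where it says the series, first, only, none or still open, it means among the compounds named here.

Three measured compounds share one core and differ only in the group attached to a saturated ring carbon. Compound 1 `COc1ccc(C2CC(c3ccc(Cl)cc3)=NN2c2nc3ccc(S(N)(=O)=O)cc3s2)cc1` carries 4-methoxyphenyl there, and in a functional assay on the whole organism (strain Wistar) for inhibition, with Rattus norvegicus as the target, read by paw edema, with stated times of 1 h and 5 h, at a dose of 20 mg/kg by the oral route (on this read-out higher numbers stand for more inhibition at the one dose given (going by the name of the read-out) and lower numbers for less inhibition), compound 1 gives 67.7%. Compound 2 `NS(=O)(=O)c1ccc2nc(N3N=C(c4ccc(Cl)cc4)CC3c3cccs3)sc2c1` carries thiophen-2-yl, and in this assay compound 2 gives 14%. Compound 3 `NS(=O)(=O)c1ccc2nc(N3N=C(c4ccc(Cl)cc4)CC3c3ccc(F)cc3)sc2c1` carries 4-fluorophenyl, and in this assay compound 3 gives 14%. Compound 3 therefore stands level with compound 2, the two together at the bottom of the three, far under compound 1: a number 53.7 percentage points lower from compound 1 to compound 3 (beyond the scatter) and a number 53.7 percentage points lower from compound 1 to compound 2 (beyond the scatter), while no change at the digits printed from compound 2 to compound 3 (within the scatter).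

Compound 4 `NS(=O)(=O)c1ccc2nc(N3N=C(c4ccc(Cl)cc4)CC3c3ccccc3Cl)sc2c1` is still to be measured. It differs from compound 3 in one place: 2-chlorophenyl in place of 4-fluorophenyl on a saturated ring carbon. Two measured steps speak to this. The large fall from compound 1 to compound 3 came with the loss of methoxy, which compound 4 does not regain. The swap from compound 2 to compound 3, one ring for another on the same carbon, left the number unchanged. Exchanging one halogen-bearing phenyl for another looks more like the second case, so the expected step in this assay is small: a number 4 percentage points higher from compound 3 to compound 4 (within the scatter). Compound 4 is thus expected to give about 18%, most likely between 5% and 40%.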

Compound 4, a percentage reported as inhibition, in the whole organism at one dose (the size of the read-out at that dose, not a potency): 14%
Compound 4: the middle estimate sits 4 percentage points above what was measured; measured number inside the range.
By their numbers in this assay, from the lowest: compounds 2, 3 and 4 (each within the scatter of the next); then compound 1.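

Swapping 4-fluorophenyl for 2-chlorophenyl on this saturated ring carbon changes both the halogen and where it sits on the phenyl ring, yet this assay shows no change at the digits printed from compound 3 to compound 4 (within the scatter) and, against the thiophene-bearing compound, no change at the digits printed from compound 2 to compound 4 (within the scatter) as well. Three different groups on this carbon, thiophen-2-yl, 4-fluorophenyl and 2-chlorophenyl, now give the same printed number, so neither of these two halogen-bearing phenyl forms lifts the reading. Compound 1 alone stands apart, with a number 53.7 percentage points lower from compound 1 to compound 4 (beyond the scatter) as the new step, and among these four compounds the high reading goes only with 4-methoxyphenyl.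

The compounds shown leave open whether that high reading needs the methoxy group itself, which a 4-hydroxyphenyl, a 4-ethoxyphenyl or a 4-(dimethylamino)phenyl on this carbon could test, while a 2-methoxyphenyl could test whether its place on the phenyl ring matters. No measurement at hand says why these three groups give the same number or why 4-methoxyphenyl stands so far from them.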